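This account rests on a few compounds, and the source may have more. Where it says the series, first, only, none or still open, it means among the compounds named here.

Three compounds have been measured in a functional assay on DU-145 cells (Homo sapiens) for cytotoxicity, read by MTT assay, with a stated time of 2 days, tested at 10 uM; a higher number here means more inhibition at the concentration tested (going by the name of the read-out), a lower number less inhibition:

- compound 1 `Fc1ccc2nc(NCCCCN3CCN(c4cccc(Cl)c4Cl)CC3)nc(NCc3ccco3)c2c1`: 95.5%
- compound 2 `Cc1cccc(N2CCN(CCCNc3nc(NCc4ccco4)c4cc(F)ccc4n3)CC2)c1C`: 95.9%
- compound 3 `CCCCNc1nc(NCc2ccco2)c2cc(F)ccc2n1`: 75.4%

Compound 1 holds the second highest of these three numbers. Its nearest neighbour is compound 2, whose number sits within the usual scatter of repeated measurements, so the two cannot be told apart on this evidence. Compound 3 is the furthest away, with a number lower than that of compound 1 by more than the scatter. Compound 3 carries only a short butyl chain on the shared core, whereas compound 1 and compound 2 each carry a chain ending in a six-membered non-aromatic ring with two nitrogens that bears an aryl group.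

Compound 4 `Cc1cccc(N2CCN(CCCCNc3nc(NCc4ccco4)c4cc(F)ccc4n3)CC2)c1C` differs from compound 1 in one place: 2,3-dimethylphenyl in place of 2,3-dichlorophenyl on an amine nitrogen in a ring. Compound 2 carries this same dimethylphenyl group, on a shorter chain, and gives 95.9%. On that basis the step from compound 1 to compound 4 is expected to be small, a number 1.5 percentage points lower from compound 1 to compound 4 (within the scatter), nothing beyond the scatter. Compound 4 is therefore estimated at 94%, with a range from 85% to 99%.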

Compound 4, a percentage reported as inhibition, at one concentration (the size of the read-out at that concentration, not a potency): 93.4%
The estimate for compound 4 lay 0.6 percentage points above the measured number; the range from low to high includes it.
By their numbers in this assay, from the lowest: compound 3; then compounds 4, 1 and 2 (each within the scatter of the next).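

Exchanging 2,3-dichlorophenyl for 2,3-dimethylphenyl on the ring amine nitrogen, with the rest of the molecule unchanged, gives in this assay a number 2.1 percentage points lower from compound 1 to compound 4 (within the scatter). Among the compounds shown here, this is the first direct comparison of these two aryl groups on the same chain, since compound 1 and compound 2 differ in chain length as well, and it shows that this assay does not separate them at the single concentration tested. Nothing measured here gives a reason for this result.

Still open, on these data alone, is whether a plain phenyl, a pyridine ring or a simple methyl group on that same nitrogen would keep the number as high as in compound 1 and compound 4. Each number gives the size of the effect at one concentration only. These two compounds could still show a stronger or weaker effect relative to each other at lower concentrations.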